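Methoxy in Place of Hydroxy on a Cytotoxic Ester Core

The source may hold more compounds than are shown below. What is called first, only, known or untested is meant among the compounds shown, and "the series" means these compounds.

Three esters of a shared core were compared in a functional assay on Jurkat cells (Homo sapiens) for cytotoxicity, read by MTT assay, with a stated time of 72 h; on this read-out higher numbers stand for weaker inhibition and lower numbers for stronger inhibition. Compound 1 `COc1ccc(C(=O)O[C@H]2CC(C)=C[C@H](OC(C)=O)[C@]3(C)[C@@H]2[C@](O)(C(C)C)C[C@@H]3O)cc1` gives 9100 nM. Compound 2 `CC1=C[C@H](OC(=O)c2ccc(O)cc2)[C@@H]2[C@](C)(CC[C@@]2(O)C(C)C)CC1=O` gives 40500 nM, the second highest of the three numbers. Compound 3 `C=C1C[C@H](OC(=O)c2ccc(O)cc2)[C@@H]2[C@](C)(CC[C@@]2(O)C(C)C)C[C@@H]1O` gives 55000 nM, a value within the scatter of compound 2, whereas compound 1 stands beyond the scatter below both. Compound 4 `COc1ccc(C(=O)O[C@H]2C=C(C)C(=O)C[C@@]3(C)CC[C@@](O)(C(C)C)[C@H]23)cc1` has not yet been measured. It differs from compound 2 by methyl in place of hydrogen on an oxygen on an aromatic ring. Since compound 1, which also carries a 4-methoxyphenyl ester, gives 9100 nM, a step toward a lower number is expected, although compound 1 differs from compound 2 at other places as well. The expected step is a 2.0-fold lower number from compound 2 to compound 4 (0.31 log units; beyond the scatter). Compound 4 is thus estimated at 20000 nM, between 7000 nM and 60000 nM.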

Compound 4, half-maximal inhibitory concentration: 40500 nM
The estimate for compound 4 lay 2.0-fold (0.31 log units) below the measured number; the range from low to high includes it.
By their numbers in this assay, from the lowest: compound 1; then compounds 2, 4 and 3 (each within the scatter of the next).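

In this assay, replacing hydroxy with methoxy on the 4-hydroxyphenyl ester gives no change at the digits printed from compound 2 to compound 4 (within the scatter). On this core, then, the hydrogen on that oxygen is not needed for the measured cytotoxicity, and methyl is accepted in its place. Nothing available accounts for this result.

From the compounds shown here alone, whether a larger group on that oxygen, such as ethyl or benzyl, or an amine in place of the hydroxy would move the number remains open. So does whether the same change would behave alike on the core of compound 1.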